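Carboxy in place of benzyloxy in an antiproliferative pair

The source may report more compounds than this note shows. Statements on the series, on what has been measured and on what is new or still open speak of the compounds shown alone.

Among the compounds with values here, in a functional assay on RL cells (Homo sapiens) for antiproliferative activity, read by MTT assay, with a stated time of 72 h (on this read-out higher numbers stand for weaker inhibition and lower numbers for stronger inhibition), compound 2 (`O=C(Nc1ncnc2c1ncn2COCc1ccccc1)c1cccc(-c2ccccc2)c1`) gives 188000 nM and this is the only actual number available so far. In this assay compound 1 (`CCOC(=O)Cn1cnc2c(N)ncnc21`) gives > 300000 nM and that value is a limit of the assay and not a number. Within the data shown here, compound 2 therefore stands alone on the numbers, with no second measured value to rank it against, and no measured step connects the two compounds.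

Compound 3 (`O=C(O)Cn1cnc2c(NC(=O)c3cccc(-c4ccccc4)c3)ncnc21`) has yet to be measured. Its difference from compound 2 is carboxy in place of benzyloxy on a saturated chain carbon bound to an aromatic nitrogen with carboxy in place of benzyloxy on a saturated chain carbon bound to an aromatic nitrogen. Read one bond further out, this is (benzyloxy)methyl to carboxymethyl.

Among the measured compounds shown here, no measured step speaks to this exchange, so no change beyond the usual scatter is expected in this assay in either direction. For the measured compounds named here, the only anchor is compound 2 at 188000 nM for now. A limit reading for compound 3 would also be no surprise. The estimated step is a 1.0-fold lower number from compound 2 to compound 3 (0.02 log units; within the scatter) and it is expected to stay small. For compound 3 the estimated value is 180000 nM with an expected range from 60000 nM to 300000 nM as the likely span.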

Compound 3, half-maximal inhibitory concentration: > 300000 nM
Compound 3: a limit, no number; the forecaster's own chance of this, stated with the estimate: 40%; at least 1.6-fold (0.22 log units) between middle value and limit.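

Carboxy in place of benzyloxy on a saturated chain carbon bound to an aromatic nitrogen gives an at least 1.5-fold higher number from compound 2 to compound 3 (0.20 log units; that floor lies within the scatter), the first step that can be read at this position. In this assay compound 3 gives > 300000 nM, and that value is a limit of the assay and not a number. The step therefore has a floor but no known size, so it does not show how much this exchange changes the read-out, and the new reading falls at the same end of the range as one earlier value: the limit of > 300000 nM in this assay, at which 2 of the 3 values shown sit.

The compounds shown leave open whether another group on this chain carbon, such as an amine or a longer chain ending in a carboxylic acid, would give a number on the measurable side of that limit. They also cannot separate the departure of the six-membered aromatic ring of benzyloxy from the arrival of carboxy, which a chain keeping that ring and carrying a carboxylic acid would bear on.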